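The compounds below may be only part of what the source reports. "The series", "measured", "known", "first", "only" and "open" are said of these compounds alone.

Series notes. Compound 1 `Cc1nc(S(C)(=O)=O)ccc1Oc1ncnc(OC2CCN(C(=O)O[C@@H](C)CF)CC2)c1F` gives 84% in a functional assay on isolated protein for inhibition of Glucose-dependent insulinotropic receptor (Rattus norvegicus), read by HTRF and cAMP accumulation (a lower number here means a smaller maximal response, a higher number a larger maximal response), level with compound 3 `Cc1nc(S(C)(=O)=O)ccc1Oc1ncnc(OC2CCN(C(=O)OC3(C(F)(F)F)COC3)CC2)c1F` at 84%, while compound 2 `Cc1nc(S(C)(=O)=O)ccc1Oc1ncnc(OC2CCN(C(=O)OC3(C(F)(F)F)CCC3)CC2)c1F` gives 82%. The steps of a number 2 percentage points lower from compound 1 to compound 2 (within the scatter) and no change at the digits printed from compound 1 to compound 3 (within the scatter) both stay within the scatter, as does a number 2 percentage points higher from compound 2 to compound 3 (within the scatter). Compound 4 `Cc1nc(S(C)(=O)=O)ccc1Oc1ncnc(OC2CCN(C(=O)C3CCCC3)CC2)c1F` is the next to be measured. Its difference from compound 1 is a group of 5 heavy atoms (5 carbon; one five-membered non-aromatic ring of carbon only) in place of a group of 5 heavy atoms (3 carbon, 1 oxygen, 1 fluorine; no ring), on a carbonyl carbon. Within the data shown here, none of the measured steps touches the carbonyl carbon itself; each exchanges a group on the oxygen next to a carbonyl group, and none moves the maximal response beyond the scatter. Those steps bear on compound 4 only loosely, so no shift beyond the scatter is expected in this assay. The expected step is a number 2 percentage points lower from compound 1 to compound 4 (within the scatter). Compound 4 is estimated at 82%, with a range from 65% to 96%.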

Compound 4, largest response reached (reported as efficacy), in percent of the reference or control that the assay uses: 83%
For compound 4 the middle estimate is 1 percentage points below the measured one; low and high end bracket the measured number.
By their numbers in this assay, from the lowest: compounds 2, 4, 1 and 3 (each within the scatter of the next).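

Cyclopentyl on a carbonyl carbon, a change at the carbonyl carbon itself rather than on the oxygen of the earlier steps, gives in this assay a number 1 percentage points lower from compound 1 to compound 4 (within the scatter) and a number 1 percentage points lower from compound 3 to compound 4 (within the scatter) and a number 1 percentage points higher from compound 2 to compound 4 (within the scatter) with all three inside the usual scatter. Among these four compounds, the maximal response therefore does not require the oxygen on this carbonyl carbon. Nothing available accounts for this flat response.

As far as these compounds go, an amine or a carboxylic acid on this carbonyl carbon remains open. So does whether any group at this place moves the maximal response beyond the scatter.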